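The source may hold more compounds than are shown below. What is called first, only, known or untested is meant among the compounds shown, and "the series" means these compounds.

Of the compounds shown here, three have been measured in an in vitro functional assay on cells for agonist activity at Bombesin receptor subtype-3 (Mus musculus), read by luminescence and calcium flux; a lower number here means that less compound is needed, a higher number that more compound is needed for the effect: compound 1 `CCCCc1cnc(C(CCCO)Cc2ccc(-c3ccccc3C(=O)O)cc2)[nH]1` gives 238 nM, compound 2 `COc1ccccc1Cc1cnc(CCc2ccc(-c3ccccc3C(=O)O)cc2)[nH]1` gives 163 nM, and compound 3 `CCCCc1cnc(C(CCC)Cc2ccc(-c3ccccc3C(=O)O)cc2)[nH]1` gives 165 nM.

Compound 2 shows the lowest of the three numbers, yet its gaps to compound 3 and to compound 1 both lie within the scatter, so the three compounds stand level in this assay. For the measured compounds named here, the one measured step, a 1.4-fold lower number from compound 1 to compound 3 (0.16 log units; within the scatter), also stayed within the scatter. Compound 4 `O=C(O)c1ccccc1-c1ccc(CCc2ncc(Cc3ccc(F)cc3)[nH]2)cc1` comes from compound 2 by a different kind of change: 4-fluorophenyl in place of 2-methoxyphenyl on a saturated chain carbon bound to an aromatic carbon. Going by the values given here, no measured step swaps one aryl group for another, so the only guide is that nothing seen so far has moved the numbers beyond the scatter. A step of a 1.0-fold higher number from compound 2 to compound 4 (0.02 log units; within the scatter) is therefore expected, with no real shift. Compound 4 is estimated at 170 nM, between 60 nM and 480 nM.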

Compound 4, half-maximal effective concentration: 50 nM
The estimate for compound 4 lay 3.4-fold (0.53 log units) above the measured number; the whole stated range lies above it.
By their numbers in this assay, from the lowest: compound 4; then compounds 2, 3 and 1 (each within the scatter of the next).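

This is the first step among these compounds to pass the scatter: 4-fluorophenyl in place of 2-methoxyphenyl on a saturated chain carbon bound to an aromatic carbon gives a 3.3-fold lower number from compound 2 to compound 4 (0.51 log units; beyond the scatter) and shows that the aryl group at this place can change the number. No evidence at hand explains this gain.

The change removes the methoxy group, adds fluorine and alters where the ring carries its substituent, all in one step, and the compounds shown do not separate these parts. Plain phenyl, 4-methoxyphenyl or 4-chlorophenyl at this place would pull them apart.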